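Removing the amide from compound 3: what to expect

The compounds below may be only part of what the source reports. "The series", "measured", "known", "first", "only" and "open" are said of these compounds alone.

Of the compounds shown here, three sharing one core have been tested in a functional assay on the whole organism (strain albino) for inhibition, with Rattus norvegicus as the target, read by paw edema, with stated times of 1 h and 2 h, at a dose of 20 mmol/kg by the intraperitoneal route; a higher number here means more inhibition at the dose given (going by the name of the read-out), a lower number less inhibition. Compound 1 `N#CC1=C(/N=C/c2ccccc2)N(c2ccccc2)C(=O)N2CCCCC(N3CCCC3)C12` gives 75.9%. Compound 2 `N#CC1=C(/N=C/c2ccc([N+](=O)[O-])cc2)N(c2ccccc2)C(=O)N2CCCCC(N3CCCC3)C12` gives 80.9%, and the step of a number 5 percentage points higher from compound 1 to compound 2 (within the scatter) is small. Compound 3 `N#CC1=C(NC(=O)c2ccccc2O)N(c2ccccc2)C(=O)N2CCCCC(N3CCCC3)C12` gives 53.8%, the lowest of the three numbers: the steps of a number 22.1 percentage points lower from compound 1 to compound 3 (beyond the scatter) and a number 27.1 percentage points lower from compound 2 to compound 3 (beyond the scatter) are both beyond the scatter.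

Compound 4 `N#CC1=C(N)N(c2ccccc2)C(=O)N2CCCCC(N3CCCC3)C12` has not yet been measured. Its difference from compound 3 is hydrogen in place of (2-hydroxyphenyl)carbonyl on an amine nitrogen. Going by the values given here, no measured step removes this group to leave a bare amine, so nothing here speaks directly to the change. The two steps that concern the group on the double-bonded ring carbon, from compound 1 and from compound 2 to compound 3, were modest, and they exchanged one aromatic group for another rather than taking it away. With that in mind, no step beyond the scatter is expected in this assay; compound 4 is estimated at 52%, in a range from 32% to 72%, a step of a number 1.8 percentage points lower from compound 3 to compound 4 (within the scatter) that is expected to stay near the number for compound 3.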

Compound 4, a percentage reported as inhibition, in the whole organism at one dose (the size of the read-out at that dose, not a potency): 86.9%
For compound 4 the middle estimate is 34.9 percentage points below the measured one; the measured number lies above the stated range.
By their numbers in this assay, from the lowest: compound 3; then compounds 1, 2 and 4 (each within the scatter of the next, the first and the last beyond it).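

In this assay, taking the (2-hydroxyphenyl)carbonyl off the amine nitrogen gives a number 33.1 percentage points higher from compound 3 to compound 4 (beyond the scatter) and shows that this group is not needed for the read-out at this position. A bare amino group does at least as well as the other two groups on that nitrogen: a number 6 percentage points higher from compound 2 to compound 4 (within the scatter) and a number 11 percentage points higher from compound 1 to compound 4 (beyond the scatter) are both far smaller steps, so the low number belongs to compound 3 and its amide alone among these four compounds. Nothing available here explains the gap.

On these data alone, it remains open whether the free amine itself matters or whether this particular amide is simply poor, a question that a small acetyl or methyl group on the nitrogen would help to settle. Also open, as far as these compounds go, is what a plain benzoyl group, without the hydroxyl, would give.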